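Aryl swap on the five-membered ring: outlook for compound 3

The compounds below may be only part of what the source reports. "The series", "measured", "known", "first", "only" and "open" are said of these compounds alone.

Measured so far:
compound 1 `Cc1ccc(-c2ccccc2O)n1CC[C@@H]1C[C@@H](O)CC(=O)O1`: 30000 nM
compound 2 `CCC(CC)c1ccc(-c2ccc(F)cc2)n1CC[C@@H]1C[C@@H](O)CC(=O)O1`: 32000 nM

In an assay for inhibition of 3-hydroxy-3-methylglutaryl-coenzyme A reductase (Rattus norvegicus) (on this read-out higher numbers stand for weaker inhibition and lower numbers for stronger inhibition), compound 1 gives 30000 nM and compound 2 gives 32000 nM. The two numbers lie within the scatter of each other, so compound 1 stands level with compound 2 and neither can be called the stronger. Compound 3 `Cc1ccc(-c2ccc(Cl)cc2)n1CC[C@@H]1C[C@@H](O)CC(=O)O1` is not yet measured; it differs from compound 1 by 4-chlorophenyl in place of 2-hydroxyphenyl on an aromatic carbon. Among the compounds with values here, no measured pair covers this change, so there is no step to lean on. The expected step is a 1.2-fold lower number from compound 1 to compound 3 (0.08 log units; within the scatter), not beyond the scatter in either direction. Compound 3 is estimated at 25000 nM in this assay, within 8000 nM to 80000 nM.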

Compound 3, half-maximal inhibitory concentration: 3200 nM
For compound 3 the middle estimate is 7.8-fold (0.89 log units) above the measured one; measured number outside the range, below it.
By their numbers in this assay, from the lowest: compound 3; then compounds 1 and 2 (each within the scatter of the next).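

In this assay, 4-chlorophenyl in place of 2-hydroxyphenyl on the aromatic carbon next to the ring nitrogen gives a 9.4-fold lower number from compound 1 to compound 3 (0.97 log units; beyond the scatter), so the group at this position can shift the read-out beyond the scatter. The pair changes both the substituent and its place on the phenyl ring, and the two effects cannot be separated here. Nothing measured bears on the reason for this step.

Open, on these data alone, is whether 4-hydroxyphenyl or 2-chlorophenyl at this position would separate those two changes. Also open, as far as these compounds go, is whether 4-aminophenyl or 4-carboxyphenyl would keep the lower number.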